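From 3-bromophenyl to 3,4-dichlorophenyl on the shared core

The compounds below may be only part of what the source reports. "The series", "measured", "known", "first", "only" and "open" are said of these compounds alone.

Measured so far in a functional assay on A549 cells (Homo sapiens) for cytotoxicity, read by MTT assay, with a stated time of 72 h; a higher number here means a weaker inhibitor, a lower number a stronger inhibitor (values in brackets):
- compound 1 `CNC(=O)c1cc(Oc2ccc(C(=O)/C=C/c3ccco3)cc2)ccn1` ("not determined" (no result reported))
- compound 2 `CNC(=O)c1cc(Oc2ccc(C(=O)/C=C/c3cccc(Br)c3)cc2)ccn1` (9940 nM)

Among the compounds with values here, compound 2 holds the only number in this assay (compound 1 has no result), so it cannot yet be ranked against another compound. Compound 3 `CNC(=O)c1cc(Oc2ccc(C(=O)/C=C/c3ccc(Cl)c(Cl)c3)cc2)ccn1` differs from compound 2 in one place (3,4-dichlorophenyl in place of 3-bromophenyl on a double-bonded chain carbon bound to a double-bonded chain carbon): 3,4-dichlorophenyl stands in place of 3-bromophenyl. Within the data shown here, no measured step guides the expectation, so only a modest move toward stronger inhibition in this assay is expected, possibly none beyond the scatter. The estimated step is small (a 1.4-fold lower number from compound 2 to compound 3 (0.15 log units; within the scatter)). Compound 3 is expected to give about 7000 nM (estimated range 2500 nM to 20000 nM).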

Compound 3, half-maximal inhibitory concentration: 33700 nM
Estimate against measurement, compound 3: 4.8-fold (0.68 log units) below; measured number outside the range, above it.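

In this assay, within the data shown here, putting 3,4-dichlorophenyl in place of 3-bromophenyl gives a 3.4-fold higher number from compound 2 to compound 3 (0.53 log units; beyond the scatter) and thus the first readable step at this position. The position therefore responds to a change of its halogenated phenyl group, and of these two groups 3-bromophenyl goes with the stronger inhibition. Nothing available explains this difference.

On these data alone, it remains open whether a phenyl group bearing an amine or a carboxylic acid in this assay would stand closer to compound 2 or to compound 3.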